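A few compounds are considered here, and "the series" means these few. Any claim that something is new, unique, unknown or untested is made for them only; others in the source may bear on it.

Measured so far:
- compound 1, `O=c1[nH]c(-c2ccco2)nc2cn(-c3ccccc3)nc12`: 1%
- compound 2, `Cc1nc2cn(Cc3ccccc3)nc2c(=O)[nH]1`: 6%

In an assay on CHO cells for displacement of a labelled ligand from adenosine receptor A1 (Homo sapiens), read by scintillation counting, with a stated time of 120 min, tested at 1 uM (a lower number here means less inhibition, a higher number more inhibition at the concentration tested (going by the name of the read-out)), compound 1 gives 1%, and in this assay compound 2 gives 6%. Among the measured compounds shown here, these are the only two numbers in the set, and they sit within the usual scatter of each other, so nothing separates compound 1 from compound 2 here; both read as essentially no displacement at the concentration tested. For the measured compounds named here, no pair of measured compounds differs in a single place, so no calibrated step is available from the measured data.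

Compound 3, `O=c1[nH]c(-c2cccs2)nc2cn(-c3ccccc3)nc12`, is to be measured in this assay. It differs from compound 1 as thiophen-2-yl in place of furan-2-yl on an aromatic carbon. With the read-out of compound 1 at 1% and compound 2 at a comparable level, the expectation for this exchange is a step in this assay of no size beyond the scatter, in no firm direction. Compound 3 is accordingly expected to give about 4% in this assay, within a range of -8% to 18%. The expected step is a number 3 percentage points higher from compound 1 to compound 3 (within the scatter).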

Compound 3, a percentage reported as inhibition, at one concentration (the size of the read-out at that concentration, not a potency): 6%
Compound 3: the middle estimate sits 2 percentage points below what was measured; measured number inside the range.
By their numbers in this assay, from the lowest: compounds 1, 2 and 3 (each within the scatter of the next).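

In this assay, among the compounds shown here, the exchange of furan-2-yl for thiophen-2-yl on the aromatic carbon between two ring nitrogen atoms gives the first step that can be read: a number 5 percentage points higher from compound 1 to compound 3 (within the scatter). This position therefore accepts a sulfur-containing five-membered aromatic ring in place of the oxygen-containing one without separating the two compounds, and compound 3 at 6%, like compound 1 at 1%, shows essentially no displacement at the concentration tested. For the compounds shown here, nothing measured here offers an explanation for this result, and with both read-outs so close to the floor, the step says only that this exchange of one five-membered aromatic ring for the other does not lift the read-out beyond the scatter.

Still open, on these data alone, is whether a different kind of group at this carbon, such as an amine or a longer alkyl chain, would give a read-out beyond the scatter of these values. Also open, as far as these compounds go, is whether the same exchange would read differently on a core carrying something other than the phenyl group of compound 1.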